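Swapping the methoxyphenyl of compound 3 for a difluorophenyl

A few compounds are considered here, and "the series" means these few. Any claim that something is new, unique, unknown or untested is made for them only; others in the source may bear on it.

Compound 3 `COc1ccc(C(=O)/C=C/c2cc(-c3cc(OC)c(OC)c(OC)c3)n[nH]2)cc1` stands second highest of the three numbers measured in a functional assay on A498 cells (Homo sapiens) for inhibition, read by sulforhodamine B assay, with a stated time of 48 h; a lower number here means a stronger inhibitor of growth, a higher number a weaker inhibitor of growth. Its nearest neighbour is compound 1 `COc1cc(-c2cc(/C=C/C(=O)c3ccc(N)cc3)[nH]n2)cc(OC)c1OC`, which gives 1640 nM. Compound 3 itself gives 1740 nM, and these two values lie within the scatter of each other. The furthest is compound 2 `COc1cc(-c2cc(/C=C/C(=O)c3ccc(Cl)c(Cl)c3)[nH]n2)cc(OC)c1OC`, which gives 5890 nM; the step of a 3.4-fold lower number from compound 2 to compound 3 (0.53 log units; beyond the scatter) is modest but beyond the scatter.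

Compound 4 `COc1cc(-c2cc(/C=C/C(=O)c3ccc(F)c(F)c3)[nH]n2)cc(OC)c1OC` differs from compound 3 in one place: 3,4-difluorophenyl in place of 4-methoxyphenyl on a carbonyl carbon. Within the data shown here, two measured steps bear on this change. The step of a 3.4-fold lower number from compound 2 to compound 3 (0.53 log units; beyond the scatter) shows that removing a 3,4-dihalogenated ring in favour of the 4-methoxyphenyl gave a modest gain, and the step of a 3.6-fold higher number from compound 1 to compound 2 (0.56 log units; beyond the scatter) shows that putting a 3,4-dihalogenated ring on the carbonyl carbon in place of an aminophenyl cost a similar modest amount. Because the step of a 3.4-fold lower number from compound 2 to compound 3 (0.53 log units; beyond the scatter) is being reversed in kind, compound 4 is expected to be a somewhat weaker inhibitor than compound 3, with the step estimated at a 2.3-fold higher number from compound 3 to compound 4 (0.36 log units; beyond the scatter). For compound 4 the expected value in this assay is 4000 nM, within a range from 1800 nM to 9000 nM.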

Compound 4, concentration for 50% growth inhibition: 2110 nM
Compound 4: the middle estimate sits 1.9-fold (0.28 log units) above what was measured; low and high end bracket the measured number.
By their numbers in this assay, from the lowest: compounds 1, 3 and 4 (each within the scatter of the next); then compound 2.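

In this assay, the 3,4-difluorophenyl on the carbonyl carbon leaves the number in the same range as the 4-methoxyphenyl and 4-aminophenyl compounds: a 1.2-fold higher number from compound 3 to compound 4 (0.08 log units; within the scatter) and a 1.3-fold higher number from compound 1 to compound 4 (0.11 log units; within the scatter) both fall inside the usual spread of repeat measurements. The earlier compounds shown here offered only one 3,4-dihalogenated ring, so they could not show whether the higher number of compound 2 went with the substitution pattern or with the halogen itself. With a 2.8-fold lower number from compound 2 to compound 4 (0.45 log units; beyond the scatter), the pattern alone does not carry that penalty, since the two rings differ in fluorine against chlorine.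

As far as these compounds go, whether a trifluoromethyl or a carboxylic acid on that phenyl would group with compounds 1, 3 and 4 or with compound 2 remains open. Nothing measured here explains why fluorine and chlorine part ways at this position.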